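Benzyl in place of cyclohexylmethyl on the piperidine amine

This account rests on a few compounds, and the source may have more. Where it says the series, first, only, none or still open, it means among the compounds named here.

Compound 2 `COc1ccc2nccc(C3CN(C4CCN(CC5CCCCC5)CC4)C(=O)O3)c2c1` gives 7940 nM in an in vitro functional assay on RBL cells for antagonist activity at C-C chemokine receptor type 8 (Homo sapiens), read by FLIPR and calcium flux (on this read-out lower numbers stand for stronger inhibition and higher numbers for weaker inhibition), the highest of the two numbers recorded. Going by the values given here, its only measured neighbour, compound 1 `COc1ccc2nccc(C3CN(C4CCN(Cc5cc6ccccc6[nH]5)CC4)C(=O)O3)c2c1`, gives 25.1 nM in this assay, and the step between them, a 320-fold higher number from compound 1 to compound 2 (2.50 log units; beyond the scatter), is the sole measured step in this set.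

Compound 3 `COc1ccc2nccc(C3CN(C4CCN(Cc5ccccc5)CC4)C(=O)O3)c2c1` differs from compound 2 by phenyl in place of cyclohexyl on a saturated chain carbon bound to an amine nitrogen in a ring. The change from compound 1 to compound 2 bears on this step only loosely: there a bicyclic aromatic group with a ring nitrogen was exchanged for a saturated carbocycle, whereas here a saturated carbocycle is exchanged for a single aromatic carbocycle of the same size. The measured step was large, so an aromatic ring in this position is expected to move the number back downward, but not all the way, since compound 3 lacks the indole of compound 1. The expected step is a 7.9-fold lower number from compound 2 to compound 3 (0.90 log units; beyond the scatter) in this assay, a reversal of part of the loss. Compound 3 is therefore estimated at 1000 nM, with a range from 200 nM to 5000 nM.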

Compound 3, half-maximal inhibitory concentration: 12600 nM
Compound 3: middle estimate off by 13-fold (1.10 log units), on the low side; measured number outside the range, above it.
By their numbers in this assay, from the lowest: compound 1; then compounds 2 and 3 (each within the scatter of the next).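

In this assay, the exchange of cyclohexyl for phenyl on a saturated chain carbon bound to an amine nitrogen in a ring gives a 1.6-fold higher number from compound 2 to compound 3 (0.20 log units; within the scatter) and so does not separate the two compounds: a single aromatic ring of carbon only and a saturated ring of the same size read alike at this position. The large distance from the indole compound therefore remains with phenyl in place, as a 500-fold higher number from compound 1 to compound 3 (2.70 log units; beyond the scatter) shows, and among these compounds only the 1H-indol-2-yl group gives a low number. Nothing measured here explains this difference.

The compounds shown leave open whether the difference rests on the second fused ring of 1H-indol-2-yl or on its ring nitrogen with the attached hydrogen, and a naphthyl group and a pyrrol-2-yl group would pull those two features apart. Also open, as far as these compounds go, is whether a phenyl ring carrying a hydroxyl group or an amine, or a longer chain to the phenyl ring, would read like compound 3 or like compound 1.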